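Compound 2 and a Smaller Group on the Nitrogen

A few compounds are considered here, and "the series" means these few. Any claim that something is new, unique, unknown or untested is made for them only; others in the source may bear on it.

In a functional assay on K562 cells (Homo sapiens) for cytotoxicity, read by MTT assay, with a stated time of 3 days (a lower number here means a stronger inhibitor, a higher number a weaker inhibitor), compound 2 (`N#Cc1c(Nc2ccccc2)nc(SCc2nc3ccccc3[nH]2)nc1-c1ccccc1`) gives the lowest of the three numbers at 3.2 nM. Compound 3 (`N#Cc1c(Nc2ccccn2)nc(SCc2nc3ccccc3[nH]2)nc1-c1ccccc1`) gives 7 nM, and compound 1 (`N#Cc1c(Cl)nc(SCc2nc3ccccc3[nH]2)nc1-c1ccccc1`) gives 11.3 nM. Compound 4 (`N#Cc1c(NC(N)=S)nc(SCc2nc3ccccc3[nH]2)nc1-c1ccccc1`) has not yet been measured. It differs from compound 2 on a nitrogen on an aromatic ring: a group of 3 heavy atoms (1 carbon, 1 nitrogen, 1 sulfur; no ring) in place of a group of 6 heavy atoms (6 carbon; one six-membered aromatic ring of carbon only), on a nitrogen on an aromatic ring.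

The closest measured change is at that same nitrogen, where pyridin-2-yl replaces phenyl, and it gives a 2.2-fold higher number from compound 2 to compound 3 (0.34 log units; beyond the scatter). Two further steps replace chloro on an aromatic carbon. Anilino gives a 3.5-fold lower number from compound 1 to compound 2 (0.55 log units; beyond the scatter), and (pyridin-2-yl)amino gives a 1.6-fold lower number from compound 1 to compound 3 (0.21 log units; within the scatter). Among the measured compounds shown here, no compound without a ring on that nitrogen has been measured, so the evidence for this change is thin. All three steps are small, and the one at that nitrogen runs upward, so a modest rise is expected in this assay. The expected step is a 2.5-fold higher number from compound 2 to compound 4 (0.40 log units; beyond the scatter). Compound 4 is estimated at 8 nM, with an expected range of 2.5 nM to 30 nM.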

Compound 4, half-maximal inhibitory concentration: 11.9 nM
Estimate against measurement, compound 4: 1.5-fold (0.17 log units) below; measured number inside the range.
By their numbers in this assay, from the lowest: compound 2; then compounds 3, 1 and 4 (each within the scatter of the next).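

In this assay, a group with no ring on the nitrogen can now be compared with the rings there: it gives a 3.7-fold higher number from compound 2 to compound 4 (0.57 log units; beyond the scatter) when phenyl leaves, but a 1.7-fold higher number from compound 3 to compound 4 (0.23 log units; within the scatter) when pyridin-2-yl leaves. Set against chloro on the aromatic carbon, the whole group that takes its place gives a 1.1-fold higher number from compound 1 to compound 4 (0.02 log units; within the scatter) and so, unlike anilino, does not separate from chloro, which shows that a ring on that nitrogen is not required for a number in the range of compound 1 and compound 3. Nothing measured on these compounds says what lies behind these differences.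

On these data alone, whether a plain amine, an acetyl group or the oxygen analogue, a urea, on that nitrogen would stand with compound 4 or with compound 2 remains open. So does the effect of a longer chain, such as an N-butyl amine, at the same place.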